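Phenyl in Place of Pyridin-4-yl: Expectation for Compound 4

A few compounds are considered here, and "the series" means these few. Any claim that something is new, unique, unknown or untested is made for them only; others in the source may bear on it.

Three compounds have been measured in an assay on CHO cells for displacement of a labelled ligand from adenosine receptor A1 (Homo sapiens), read by scintillation counting, tested at 10 uM; a lower number here means less inhibition, a higher number more inhibition at the concentration tested (going by the name of the read-out):

Compound 1 `CC(C)(C)c1csc(N)c1C(=O)c1ccc(Cl)cc1`: 1%
Compound 2 `CC(C)(C)Cc1c(-c2ccncc2)sc(N)c1C(=O)c1ccc(Cl)cc1`: 1%
Compound 3 `CC(C)(C)Cc1c(Br)sc(N)c1C(=O)c1cccc(C(F)(F)F)c1`: 1%

Compound 2 stands level with compounds 1 and 3 at the digits shown: against compound 1, its nearest neighbour, there is no change within the scatter, and against compound 3, the furthest, none either. All three show almost no inhibition.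

Compound 4 `CC(C)(C)Cc1c(-c2ccccc2)sc(N)c1C(=O)c1ccc(Cl)cc1` has not yet been measured. It differs from compound 2 in one place: phenyl in place of pyridin-4-yl on an aromatic carbon.

Among the compounds with values here, with no step between measured compounds to lean on, and the values so uniformly low, the expected step in this assay is none beyond the scatter, that is a number 2 percentage points higher from compound 2 to compound 4 (within the scatter). Compound 4 is therefore estimated at 3%, with a range from 0% to 15%.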

Compound 4, a percentage reported as inhibition, at one concentration (the size of the read-out at that concentration, not a potency): 1%
The estimate for compound 4 lay 2 percentage points above the measured number, and the stated range covers the measured number.
By their numbers in this assay, from the lowest: compounds 1, 2, 3 and 4 (each within the scatter of the next).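

Phenyl in place of pyridin-4-yl in this assay gives no change at the digits printed from compound 2 to compound 4 (within the scatter). Within the data shown here, this is the first direct comparison at this aromatic carbon next to the ring sulfur: removing the hydrogen-bond acceptor counted for pyridin-4-yl leaves the number in place, but with almost no inhibition on either side, the pair says little about what this position can do. No measurement shown offers an explanation for this result. The compounds shown leave open whether an amine or a carboxylic acid on this carbon would give clear inhibition, and whether a longer chain in place of neopentyl would.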